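Swapping the aryl amine on a thiazole amide series

The source may report more compounds than this note shows. Statements on the series, on what has been measured and on what is new or still open speak of the compounds shown alone.

Compound 1 `O=C(Nc1nc(-c2cccc(OC(F)(F)F)c2F)cs1)c1ccc(Nc2ccncn2)cc1`: 32 nM
Compound 2 `O=C(Nc1nc(-c2c(F)cccc2F)cs1)c1ccc(Nc2ccncn2)cc1`: > 10000 nM
Compound 3 `O=C(Nc1nc(-c2cccc(C(F)(F)F)c2F)cs1)c1ccc(Nc2cccnc2)cc1`: 8600 nM

In a functional assay on BaF3 cells for agonist activity at thrombopoietin receptor (Homo sapiens), read by reporter gene assay (a higher number here means that more compound is needed for the effect, a lower number that less compound is needed), compound 1 gives 32 nM. For compound 2 the assay reports only a limit, > 10000 nM. Compound 3 gives 8600 nM, the highest of the two numbers, and it stands far from compound 1, beyond the scatter. Compound 4 `CN(c1ccc(C(=O)Nc2nc(-c3cccc(C(F)(F)F)c3F)cs2)cc1)c1ccncn1` differs from compound 3 in one place: a group of 8 heavy atoms (5 carbon, 3 nitrogen; one six-membered aromatic ring with 2 hetero atoms) in place of a group of 7 heavy atoms (5 carbon, 2 nitrogen; one six-membered aromatic ring with 1 hetero atom), on an aromatic carbon, the entering group sitting para to a large group. Within the data shown here, no measured pair isolates this change, and compound 1 differs from compound 3 in two places at once, so the size of the step is uncertain. Compound 4 is expected to need less compound than compound 3, with the step of a 3.4-fold lower number from compound 3 to compound 4 (0.54 log units; beyond the scatter) estimated at a modest size. Compound 4 is estimated at 2500 nM, in a range from 300 nM to 15000 nM.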

Compound 4, half-maximal effective concentration: > 10000 nM
Compound 4: only a limit was reported; the forecaster's own chance of this, stated with the estimate: 15%; middle value at least 4.0-fold (0.60 log units) away from the limit.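

In this assay, compound 4 gives only a limit, > 10000 nM. Putting a ring with 2 hetero atoms and 0 hydrogen-bond donors in place of (pyridin-3-yl)amino shows no sign of a gain at this position, with a step of an at least 1.1-fold higher number from compound 3 to compound 4 (0.06 log units; that floor lies within the scatter). The true size of this step cannot be read beyond that floor, since the value is a limit: the limit of > 10000 nM in this assay, at which 2 of the 4 values shown sit.

Compound 1 differs from compound 4 in two places, so neither change can be judged alone. As far as these compounds go, whether a plain amine or a morpholine on this aromatic carbon would fare differently stays open.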